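Cytotoxicity notes: trifluoromethoxy in place of methoxycarbonyl

A few compounds are considered here, and "the series" means these few. Any claim that something is new, unique, unknown or untested is made for them only; others in the source may bear on it.

Among the compounds with values here, in an ADME assay on Raji cells (Homo sapiens) for cytotoxicity, with a stated time of 72 h (a higher number here means that more compound is needed for the effect, a lower number that less compound is needed), compound 3 (`COC(=O)c1cccc(NC(=O)Nc2cc(C)nc3ccccc23)c1`) gives 26000 nM, the only actual number so far. Compound 1 (`Cc1cc(NC(=O)Nc2cccc([N+](=O)[O-])c2)c2ccccc2n1`) reads > 25000 nM, which is a limit of the assay and not a number. Compound 2 (`Cc1cc(NC(=O)Nc2ccc(F)c(F)c2)c2ccccc2n1`) reads > 25000 nM, which is likewise a limit. The series is thus marked by the limit of > 25000 nM in this assay, at which 2 of the 3 values shown sit.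

Compound 4 (`Cc1cc(NC(=O)Nc2cccc(OC(F)(F)F)c2)c2ccccc2n1`) is the next one to follow, and the change from compound 3 is trifluoromethoxy in place of methoxycarbonyl on an aromatic carbon. In short, trifluoromethoxy stands in place of methoxycarbonyl on an aromatic carbon, with the rest of the structure unchanged.

Within the data shown here, only one measured step touches this position: a step that the limit leaves unreadable from compound 1 to compound 3. It gives no size to carry over, so the data offer no sign of a large effect from the group at this place, and no firm proof against one either. The value of compound 3 at 26000 nM is therefore the best anchor, and no step beyond the scatter is expected in this assay. The expected result is a 1.2-fold lower number from compound 3 to compound 4 (0.07 log units; within the scatter). For compound 4 the estimated value is 22000 nM, with an expected range of 9000 nM to 45000 nM.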

Compound 4, half-maximal effective concentration: 9000 nM
Compound 4: middle estimate off by 2.4-fold (0.39 log units), on the high side; low and high end bracket the measured number.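

At this place on the aromatic ring, the group does move the number in this assay: trifluoromethoxy in place of methoxycarbonyl gives a 2.9-fold lower number from compound 3 to compound 4 (0.46 log units; beyond the scatter). Trifluoromethoxy in place of nitro gives an at least 2.7-fold lower number from compound 1 to compound 4 (0.44 log units; beyond the scatter), and the starting value of that step is a limit of the assay and not a number, so its size is only a lower bound. The position now has readable steps, where the earlier step on it could not be read, yet the series still rests largely on a single limit: the limit of > 25000 nM in this assay, at which 2 of the 4 values shown sit.

As far as these compounds go, whether the lower number is particular to trifluoromethoxy, or would also appear with a simple amine, a carboxylic acid or a chlorine at the same place, remains open. The shared core stays the same in every compound shown, and the effect of a longer chain in place of its methyl remains open too.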